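This account rests on a few compounds, and the source may have more. Where it says the series, first, only, none or still open, it means among the compounds named here.

Compound 1 `COc1c(NC(=O)C(C)F)cccc1C(=O)Nc1ccccc1` — > 632 uM
Compound 2 `COc1cc(NC(=O)C(C)F)cc(C(=O)Nc2ccccc2)c1` — 491 uM

Of the compounds shown here, two have been tested in an ADME assay on MDCK cells (Canis lupus familiaris) for cytotoxicity, read by cytopathic effect, with a stated time of 48 h; on this read-out lower numbers stand for higher toxicity in this test and higher numbers for lower toxicity in this test. Compound 1 gives > 632 uM, which is a limit of the assay rather than a number; it sits at the limit of > 632 uM in this assay, at which 1 of the 2 values shown sits. Among the measured compounds shown here, compound 2 gives 491 uM in this assay, and this is the only actual number in the set, so compound 2 stands as the sole measured point. For the measured compounds named here, no pair of measured compounds differs in a single place, so no measured step can be drawn from these two values.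

Compound 3 `CC(F)C(=O)Nc1cccc(C(=O)Nc2ccccc2)c1` has not yet been tested in this assay. It differs from compound 2 by hydrogen in place of methoxy on an aromatic carbon. Going by the values given here, there is no measured step on which to base a direction, so the step from compound 2 to compound 3 is expected to be small in either direction, within the scatter, and a reported limit is a real possibility. Compound 3 is therefore estimated at 500 uM in this assay, with a range from 250 uM to 650 uM, corresponding to an expected step of a 1.0-fold higher number from compound 2 to compound 3 (0.01 log units; within the scatter).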

Compound 3, half-maximal toxic concentration: 579 uM
Beside the measured number, compound 3's estimate is 1.2-fold (0.06 log units) below it, within the range that was stated.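

Among the compounds shown here, the first measured step at this aromatic carbon, meta to the ((1-fluoroethyl)carbonyl)amino group, shows that in this assay hydrogen in place of methoxy gives a 1.2-fold higher number from compound 2 to compound 3 (0.07 log units; within the scatter), so the methoxy there makes no difference that can be told from the usual scatter of this test. A second reading of the same exchange, with the methoxy at a different place on the ring, gives an at least 1.0-fold lower number from compound 1 to compound 3 (0.03 log units; that floor lies within the scatter), and only a floor can be read from this step, which lies within the scatter and so shows no change that can be relied on. Compound 1 carries a limit of the assay and not a number: the limit of > 632 uM in this assay, at which 1 of the 3 values shown sits.

The compounds shown leave open whether a larger change at this aromatic carbon, such as an amine, a carboxylic acid or a longer alkoxy chain in place of the methoxy, would move the number beyond the scatter. They also leave open the true value of compound 1, and with it the real size of the step that starts from that compound.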